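Cytotoxicity in a fused-core series: from compound 2 to compound 4

The source may hold more compounds than are shown below. What is called first, only, known or untested is meant among the compounds shown, and "the series" means these compounds.

Measured compounds:
compound 1, `COc1ccc(-c2nc(C(F)(F)S(=O)(=O)c3cccc(Cl)c3)nc3ccsc23)cn1`: > 50000 nM
compound 2, `COc1ccc(Nc2nc(CS(=O)(=O)c3cccc(Cl)c3)nc3ccsc23)cc1`: 60000 nM
compound 3, `COc1ccc(-c2nc(CCc3cccc(Cl)c3)nc3ccsc23)cn1`: > 50000 nM

The three compounds share a fused core and were tested in an ADME assay on cells (Homo sapiens) for cytotoxicity, read by resazurin assay, with a stated time of 5 days; on this read-out higher numbers stand for lower toxicity in this test and lower numbers for higher toxicity in this test. Compound 1 reaches only the limit of the test, > 50000 nM, and gives no number. Compound 3 likewise stops at the limit, > 50000 nM. Two of the three values therefore sit at the limit of > 50000 nM in this assay, at which 2 of the 3 values shown sit. Within the data shown here, compound 2 stands as the only compound with a number, 60000 nM.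

Compound 4, `O=S(=O)(Cc1nc(-c2cccs2)c2sccc2n1)c1cccc(Cl)c1`, has not yet been measured in this assay. It differs from compound 2 in one place: thiophen-2-yl in place of (4-methoxyphenyl)amino on an aromatic carbon. Since compound 2 already shows low toxicity and the other two compounds give only limits, the step from compound 2 to compound 4 is expected to be none beyond the usual scatter, and compound 4 is expected to give 55000 nM, with a range of 20000 nM to 150000 nM, quite possibly as a limit again; the expected step is a 1.1-fold lower number from compound 2 to compound 4 (0.04 log units; within the scatter).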

Compound 4, half-maximal cytotoxic concentration: > 50000 nM
Compound 4 gave a limit, no number; the forecaster's own chance of this, stated with the estimate: 60%; the middle value does not contradict the limit.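

In this assay compound 4 gives > 50000 nM, a limit and not a number. Among these compounds, no step from compound 2 to compound 4 can therefore be read. The compounds shown leave open where the true values of compound 1, compound 3 and compound 4 lie: the limit of > 50000 nM in this assay, at which 3 of the 4 values shown sit.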